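From Chloropropanamide to Cyclopropylurea on a Sulfonate Scaffold

This account rests on a few compounds, and the source may have more. Where it says the series, first, only, none or still open, it means among the compounds named here.

In a functional assay on HT-29 cells (Homo sapiens) for antiproliferative activity, read by sulforhodamine B assay, with a stated time of 48 h (on this read-out higher numbers stand for weaker inhibition and lower numbers for stronger inhibition), compound 2 `O=C(CCCl)Nc1ccc(S(=O)(=O)Oc2ccccc2I)cc1` gives 14000 nM, and compound 1 `CC(C)c1ccccc1OS(=O)(=O)c1ccc(NC(=O)CCCl)cc1` gives 16000 nM; the two numbers cannot be told apart, as the step of a 1.1-fold lower number from compound 1 to compound 2 (0.06 log units; within the scatter) shows. Compound 3 `O=C(Nc1ccc(S(=O)(=O)Oc2ccccc2I)cc1)NC1CC1` differs from compound 2 by cyclopropylamino in place of 2-chloroethyl on a carbonyl carbon. Among the measured compounds shown here, no measured step touches this carbonyl position; the single measured step concerns a substituent on an aromatic carbon and offers no guidance here. With nothing to lean on, a step of a 1.4-fold higher number from compound 2 to compound 3 (0.15 log units; within the scatter) is expected, not beyond the scatter. The value of compound 3 in this assay is estimated at 20000 nM, within 5000 nM to 60000 nM.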

Compound 3, half-maximal inhibitory concentration: 14000 nM
Compound 3: the middle estimate sits 1.4-fold (0.15 log units) above what was measured; the range from low to high includes it.
By their numbers in this assay, from the lowest: compounds 2, 3 and 1 (each within the scatter of the next).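

Among the compounds shown here, this is the first measured step at the carbonyl carbon, and in this assay the swap of 2-chloroethyl for cyclopropylamino reads (no change at the digits printed from compound 2 to compound 3 (within the scatter)). Compound 3 has no chlorine and brings a three-membered ring and a hydrogen-bond donor, yet its number cannot be told from that of compound 2, so with iodo on the aromatic carbon, 2-chloroethyl is not needed to keep this level of activity. No measurement at hand explains this result.

As far as these compounds go, whether a longer chain or a carboxylic acid on this carbonyl carbon would move the number beyond the scatter stays open. So does whether cyclopropylamino reads the same with isopropyl in place of iodo.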